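This account rests on a few compounds, and the source may have more. Where it says the series, first, only, none or still open, it means among the compounds named here.

Of the compounds shown here, three built on one shared core have been tested in a functional assay on Ehrlich cells (Mus musculus) for cytotoxicity, read by trypan blue exclusion, with a stated time of 2 h, tested at 100 ug/mL; on this read-out lower numbers stand for a weaker effect and higher numbers for a stronger effect at the one concentration tested. Compound 1 `N#CC1=C(NC(=O)c2ccccc2)N(c2ccc(S(N)(=O)=O)cc2)C2=C(C(=O)CCC2)C1c1ccc(Cl)cc1Cl` gives 75% in this assay. Compound 2 `NC(=O)C1=C(N)N(c2ccc(S(N)(=O)=O)cc2)C2=C(C(=O)CCC2)C1c1ccc(Cl)cc1Cl` gives 45%, and compound 3 `N#CC1=C(/N=C/c2ccc([N+](=O)[O-])cc2[N+](=O)[O-])N(c2ccc(S(N)(=O)=O)cc2)C2=C(C(=O)CCC2)C1c1ccc(Cl)cc1Cl` gives 20%; both of these numbers lie below that of compound 1 by more than the usual scatter, so compound 1 shows the strongest effect of the three in this assay. Among the measured compounds shown here, no pair of these measured compounds differs in just one place, so none of them shows a single isolated change and its consequence.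

Compound 4 `CC(=O)CC(=O)NC1=C(C#N)C(c2ccc(Cl)cc2Cl)C2=C(CCCC2=O)N1c1ccc(S(N)(=O)=O)cc1` has not yet been measured. It differs from compound 1 in one place: 2-oxopropyl in place of phenyl on a carbonyl carbon. Cut one bond further out, the same difference reads benzoyl to (2-oxopropyl)carbonyl. For the measured compounds named here, nothing among the measured compounds shows how this assay responds to such a change, so the expectation rests on compound 1 alone. The step of a number 15 percentage points lower from compound 1 to compound 4 (beyond the scatter) is expected to be a modest fall, possibly not beyond the scatter. Compound 4 is expected to give about 60% in this assay, within a range from 35% to 80%.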

Compound 4, a percentage reported as activity, at one concentration (the size of the read-out at that concentration, not a potency): 80%
Beside the measured number, compound 4's estimate is 20 percentage points below it, and the stated range covers the measured number.
By their numbers in this assay, from the lowest: compound 3; then compound 2; then compounds 1 and 4 (each within the scatter of the next).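

In this assay, replacing phenyl with 2-oxopropyl on the carbonyl carbon gives a number 5 percentage points higher from compound 1 to compound 4 (within the scatter) and so leaves the effect unchanged as far as this read-out can tell. Among the compounds shown here, this is the first single change seen here, and it shows that the aromatic ring of the benzoyl group is not required at this position for the effect at the one concentration tested, since a chain with no ring and an extra hydrogen-bond acceptor serves equally well. No accompanying measurement offers a reason for this.

As far as these compounds go, it remains open whether a simple methyl, a longer chain or a carboxylic acid on the same carbonyl carbon would also hold the effect. A single concentration also leaves open whether compound 1 and compound 4 would match in potency across a range of concentrations.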